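This account rests on a few compounds, and the source may have more. Where it says the series, first, only, none or still open, it means among the compounds named here.

Measured so far:
Compound 1 `COc1cc(OC)c(OC)cc1/C=C/C(=O)c1cc(OC(C)=O)ccc1OC(C)=O`: in a functional assay on HeLa cells (Homo sapiens) for inhibition, read by MTT assay, with a stated time of 72 h (a higher number here means a weaker inhibitor, a lower number a stronger inhibitor), compound 1 gives 57900 nM.
Compound 2 `COc1cc(OC)c(OC)cc1/C=C/C(=O)c1cc(Cl)ccc1O`: in this assay compound 2 gives > 150000 nM, which is a limit of the assay and not a number.
Compound 3 `COc1cc(OC)c(-c2cc(=O)c3cc(O)ccc3o2)cc1OC`: in this assay compound 3 gives > 150000 nM, likewise a limit of the assay.

Compound 2 therefore stands at the upper edge of what this assay can report, and it is not alone there: the limit of > 150000 nM in this assay, at which 2 of the 3 values shown sit. Only compound 1 yields an actual number, and that number itself points to weak inhibition.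

Compound 4 `COc1cc(OC)c(OC)cc1/C=C/C(=O)c1ccc(Cl)cc1` has not yet been measured. It differs from compound 2 in one place: 4-chlorophenyl in place of 5-chloro-2-hydroxyphenyl on a carbonyl carbon. The expected effect of this change on this assay cannot be read from any measured pair, since no step between measured compounds is shown. Given that compound 2 stands at > 150000 nM, a limit, the step is expected to be small or within the scatter, with the value of compound 4 more likely to fall just inside the range the assay can report. Compound 4 is estimated at 100000 nM, between 30000 nM and 200000 nM, and the step from compound 2 to compound 4 is expected as an at least 1.5-fold lower number from compound 2 to compound 4 (0.17 log units; that floor lies within the scatter).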

Compound 4, half-maximal inhibitory concentration: 36500 nM
The estimate for compound 4 lay 2.7-fold (0.44 log units) above the measured number, and the stated range covers the measured number.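

In this assay, going by these compounds alone, putting 4-chlorophenyl in place of 5-chloro-2-hydroxyphenyl on the carbonyl carbon gives an at least 4.1-fold lower number from compound 2 to compound 4 (0.61 log units; beyond the scatter), so this position does respond to change, which the earlier compounds could not show. This one step combines the loss of the hydroxy group with a different placing of the chlorine, so it cannot be credited to either alone. Compound 2 stands at a limit of the assay and not at a number, so the step gives only a floor for the true difference: the limit of > 150000 nM in this assay, at which 2 of the 4 values shown sit.

As far as these compounds go, whether the lower number needs the chlorine at all stays open, as a plain phenyl group would be required to test that. Also open, from the compounds shown here alone, is how an amine or a carboxylic acid in the chlorine's place on this ring would read out.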